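The source may report more compounds than this note shows. Statements on the series, on what has been measured and on what is new or still open speak of the compounds shown alone.

Measured compounds:
Compound 1, `CCc1ccc(Cn2c(CCc3ccccc3)nnc2[C@H](NC(=O)c2ccccn2)c2c[nH]c3ccccc23)cc1` — 67 nM
Compound 2, `O=C(N[C@H](c1c[nH]c2ccccc12)c1nnc(CCc2ccccc2)n1-c1ccccc1)c1ccccn1` — 105 nM
Compound 3, `O=C(N[C@H](c1c[nH]c2ccccc12)c1nnc(CCc2c[nH]c3ccccc23)n1-c1ccccc1)c1ccccn1` — 160 nM

In an in vitro assay on LLC-PK1 cells for displacement of a labelled ligand from growth hormone secretagogue receptor type 1 (Homo sapiens) (a lower number here means a stronger inhibitor, a higher number a weaker inhibitor), compound 2 gives 105 nM, the second highest of the three numbers. Its neighbours sit close on either side: the step of a 1.6-fold higher number from compound 1 to compound 2 (0.20 log units; within the scatter) and the step of a 1.5-fold higher number from compound 2 to compound 3 (0.18 log units; within the scatter) are both within the scatter, so on the numbers shown compound 2 cannot be told apart from compound 1 or compound 3.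

Compound 4, `O=C(Cc1ccccn1)N[C@H](c1c[nH]c2ccccc12)c1nnc(CCc2ccccc2)n1-c1ccccc1`, differs from compound 2 in one place: (pyridin-2-yl)methyl in place of pyridin-2-yl on a carbonyl carbon. Neither measured step bears directly on this part of the molecule. The step from compound 1 to compound 2 altered the group on the aromatic nitrogen of the core, and the step from compound 2 to compound 3 altered the saturated chain; the amide carbonyl and its pyridine were untouched in both. What the two steps do show is that the shared core has so far tolerated changes without moving beyond the scatter. The expectation for compound 4 in this assay is therefore a small step, a 1.9-fold higher number from compound 2 to compound 4 (0.28 log units; within the scatter), with no direction that the data can support. Compound 4 is estimated at 200 nM, within a range of 70 nM to 600 nM.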

Compound 4, half-maximal inhibitory concentration: 700 nM
Compound 4: middle estimate off by 3.5-fold (0.54 log units), on the low side; the whole stated range lies below it.
By their numbers in this assay, from the lowest: compounds 1, 2 and 3 (each within the scatter of the next, the first and the last beyond it); then compound 4.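

In this assay, the step of a 6.7-fold higher number from compound 2 to compound 4 (0.82 log units; beyond the scatter) is the only step shown that lies beyond the scatter, and it comes from placing (pyridin-2-yl)methyl where pyridin-2-yl stood on a carbonyl carbon, with the six-membered aromatic ring and the counts of hydrogen-bond donors and acceptors unchanged. For the compounds shown here, this position therefore responds to a change of a kind that the earlier compounds could not reveal, since the steps at the group on the aromatic nitrogen and at the saturated chain both stayed within the scatter, although each of those sites is represented by a single change only. No measurement shown here accounts for the size of this step.

With only these two groups shown on this carbonyl carbon, it remains open whether the weaker binding value follows from the added carbon itself or would appear with other groups at this place, such as phenyl, pyridin-3-yl or a longer chain like 2-(pyridin-2-yl)ethyl. Going by these compounds, it is also open whether the same change would have a step of similar size on the compound 1 framework, which carries 4-ethylbenzyl on the aromatic nitrogen.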